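The source may hold more compounds than are shown below. What is called first, only, known or untested is meant among the compounds shown, and "the series" means these compounds.

Compound 3 `Cc1ccc(-c2nc(NN)c3cc(Cl)ccc3n2)cc1` carries an amino group on a nitrogen on an aromatic ring of the shared core. In a functional assay on HeLa cells (Homo sapiens) for antiproliferative activity, read by MTT assay, with a stated time of 48 h (a higher number here means a weaker inhibitor, a lower number a stronger inhibitor), compound 3 gives 3.98 ug/mL, the second highest of the three numbers measured: compound 1 `Cc1ccc(-c2nc(N)c3cc(Cl)ccc3n2)cc1` gives 3.56 ug/mL, and compound 2 `Cc1ccc(-c2nc(NO)c3cc(Cl)ccc3n2)cc1` gives 12.7 ug/mL. The step of a 1.1-fold higher number from compound 1 to compound 3 (0.05 log units; within the scatter) lies within the scatter, while a 3.6-fold higher number from compound 1 to compound 2 (0.55 log units; beyond the scatter) and a 3.2-fold lower number from compound 2 to compound 3 (0.50 log units; beyond the scatter) are modest. Compound 4 `Cc1ccc(-c2nc(NC(=O)c3ccccc3)c3cc(Cl)ccc3n2)cc1` differs from compound 3 by benzoyl in place of amino on a nitrogen on an aromatic ring. Within the data shown here, no measured step introduces a group of this size, so the three steps bear on it only loosely; the largest among them is modest, and a move of similar or smaller size is expected, with the direction uncertain: a 1.5-fold higher number from compound 3 to compound 4 (0.18 log units; within the scatter). Compound 4 is therefore expected to give about 6 ug/mL in this assay, between 2 ug/mL and 20 ug/mL.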

Compound 4, half-maximal inhibitory concentration: 16.2 ug/mL
For compound 4 the middle estimate is 2.7-fold (0.43 log units) below the measured one; low and high end bracket the measured number.
By their numbers in this assay, from the lowest: compounds 1 and 3 (each within the scatter of the next); then compounds 2 and 4 (each within the scatter of the next).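

In this assay, among these compounds, the benzoyl group, the first large group at this nitrogen, gives a 4.6-fold higher number from compound 1 to compound 4 (0.66 log units; beyond the scatter) and a 4.1-fold higher number from compound 3 to compound 4 (0.61 log units; beyond the scatter), so this position does not carry every group without a shift in the number. The comparison with the much smaller hydroxy group gives only a 1.3-fold higher number from compound 2 to compound 4 (0.11 log units; within the scatter), so group size alone does not order these compounds. Nothing available explains these shifts.

From the compounds shown here alone, whether the carbonyl or the added ring matters more stays open. An acetyl group or a benzyl group on the same nitrogen would separate the two.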